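Adding a Methyl Where No Growth Inhibition Was Seen

The source may hold more compounds than are shown below. What is called first, only, known or untested is meant among the compounds shown, and "the series" means these compounds.

Compound 1 `CCc1cc(=O)c2ccc(Sc3cccc(Cl)n3)cc2o1` was tested in a functional assay on A549 cells (Homo sapiens) for antiproliferative activity, read by sulforhodamine B assay, with a stated time of 72 h; on this read-out higher numbers stand for weaker inhibition of growth and lower numbers for stronger inhibition of growth. For compound 1 the result is a limit of the assay, > 31400 nM, and not a number. Compound 2 `CCc1cc(=O)c2ccc(Sc3cccc(Cl)n3)c(C)c2o1` differs from compound 1 by methyl in place of hydrogen on an aromatic carbon. For compound 2 this assay again reports only a limit, > 30100 nM. The step between the two is therefore a step that the two limits leave unreadable from compound 1 to compound 2; the two limits the limit of > 30100 nM in this assay, at which 1 of the 3 values shown sits, and the limit of > 31400 nM in this assay, at which 1 of the 3 values shown sits, are all that is known of it. Compound 3 `CCc1cc(=O)c2ccc(OCc3ccccc3)c(C)c2o1` is built on a different core, and the difference between the two cores is not broken down here. For compound 3 this assay also gives only a limit, > 33900 nM.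

Compound 4 `CCc1cc(=O)c2ccc(OCc3cccc(C)c3)c(C)c2o1` has not been measured. It differs from compound 3 by methyl in place of hydrogen on an aromatic carbon. Going by the values given here, this is the same kind of change as the one from compound 1 to compound 2, but the surroundings are not the same: in compound 2 the methyl sits on a six-membered aromatic ring of carbon only, part of a fused or bridged system of two rings, ortho to a fused ring, ortho to a group of 8 heavy atoms and meta to a fused ring, whereas in compound 4 it sits on a six-membered aromatic ring of carbon only, meta to a large group. Among the compounds with values here, every value so far is a limit, as the limit of > 33900 nM in this assay, at which 1 of the 3 values shown sits, shows, and the one measured step is unreadable. In this assay the expected step is a step that the limit leaves unreadable from compound 3 to compound 4, an estimate that rests on the unreadable a step that the two limits leave unreadable from compound 1 to compound 2 and on all three values being limits. Compound 4 is therefore expected to give about 40000 nM, most likely between 8000 nM and 150000 nM, and quite possibly only another limit.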

Compound 4, concentration for 50% growth inhibition: 24900 nM
Beside the measured number, compound 4's estimate is 1.6-fold (0.21 log units) above it, within the range that was stated.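

On the core of compound 3, the change from phenyl to 3-methylphenyl gives an at least 1.3-fold lower number from compound 3 to compound 4 (0.13 log units; that floor lies within the scatter) in this assay, and compound 4 is the only compound shown with an actual number rather than a limit of the assay; the true step could be larger, but the size that can be vouched for does not clear ordinary scatter. The same swap of hydrogen for methyl on the core of compound 1 cannot be read, as the step to compound 2 runs between two values that are both only limits. This does not show that the change carries over from one core to the other, nor that it fails to, and the methyl of compound 4 sits in different surroundings, on a ring meta to a large group, so a single readable step on one core says nothing firm about the other.

Open, from the compounds shown here alone, is where the true value of compound 3 lies, and with it the real size of the step. Also open, going by these compounds, is whether another group in the place of this methyl, such as an amine, a carboxylic acid or a longer chain, would give a lower number in this assay.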